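The compounds below may be only part of what the source reports. "The series", "measured", "known", "first", "only" and "open" are said of these compounds alone.

Measured so far in a functional assay on HepG2 cells (Homo sapiens) for antiproliferative activity, read by MTT assay, with a stated time of 24 h; a higher number here means a weaker inhibitor, a lower number a stronger inhibitor
- compound 1 `COc1cc(OC)c(-c2coc3cc(OCc4ccccc4)ccc3c2=O)cc1OC` gives 1320 nM
- compound 2 `COc1cc(OC)c(-c2coc3cc(OCc4ccccc4Cl)ccc3c2=O)cc1OC` gives 1690 nM
- compound 3 `COc1cc(OC)c(-c2coc3cc(OCc4ccc(C(F)(F)F)cc4)ccc3c2=O)cc1OC` gives 890 nM

Compound 3 stands at 890 nM and is not separated from the other two compounds, with a 1.5-fold lower number from compound 1 to compound 3 (0.17 log units; within the scatter) and a 1.9-fold lower number from compound 2 to compound 3 (0.28 log units; within the scatter) as its steps.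

Compound 4 `COc1cc(OC)c(-c2coc3cc(OCc4cccc(C(F)(F)F)c4)ccc3c2=O)cc1OC` has the same atoms as compound 3, joined differently: 3-(trifluoromethyl)phenyl in place of 4-(trifluoromethyl)phenyl on a saturated chain carbon bound to an oxygen on an aromatic ring.

Going by the values given here, no measured step shows this exact exchange, so the evidence is indirect. Trifluoromethyl in place of hydrogen gave a 1.5-fold lower number from compound 1 to compound 3 (0.17 log units; within the scatter) and chloro in place of hydrogen gave a 1.3-fold higher number from compound 1 to compound 2 (0.11 log units; within the scatter) and neither step leaves the scatter. On that basis no step beyond the scatter is expected in this assay and no direction is favoured. The estimated step is a 1.1-fold higher number from compound 3 to compound 4 (0.05 log units; within the scatter) and it is expected to stay within the scatter. The estimate for compound 4 is 1000 nM with an expected range from 550 nM to 1800 nM for the measurement still to come.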

Compound 4, half-maximal inhibitory concentration: 610 nM
For compound 4 the middle estimate is 1.6-fold (0.21 log units) above the measured one; measured number inside the range.
By their numbers in this assay, from the lowest: compounds 4, 3, 1 and 2 (each within the scatter of the next, the first and the last beyond it).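

In this assay, 3-(trifluoromethyl)phenyl in place of 4-(trifluoromethyl)phenyl on a saturated chain carbon bound to an oxygen on an aromatic ring leaves the two isomers unseparated, with a 1.5-fold lower number from compound 3 to compound 4 (0.16 log units; within the scatter), so 3-(trifluoromethyl)benzyl and 4-(trifluoromethyl)benzyl cannot be ranked at this position. The series now shows its first steps beyond the scatter: trifluoromethyl in place of hydrogen on an aromatic carbon gives a 2.2-fold lower number from compound 1 to compound 4 (0.34 log units; beyond the scatter), although compound 3, with the same group in its 4-(trifluoromethyl)phenyl, stays within the scatter of compound 1, and 3-(trifluoromethyl)phenyl in place of 2-chlorophenyl gives a 2.8-fold lower number from compound 2 to compound 4 (0.44 log units; beyond the scatter). Both steps are modest, and no accompanying measurement offers an explanation for them.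

The compounds shown carry only chloro or trifluoromethyl on the phenyl of the benzyl group, so it remains open whether an amine or a carboxylic acid on that phenyl would give a step beyond the scatter from compound 1. Also open, going by these compounds, is whether a longer chain between the oxygen and the phenyl would keep the values of this series.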